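Acylated piperazine in place of a basic bipiperidine

The source may report more compounds than this note shows. Statements on the series, on what has been measured and on what is new or still open speak of the compounds shown alone.

Measured compounds:
compound 1, `C[C@H](NC(=O)c1c(CN2CCC(N)CC2)c(-c2ccccc2)nc2ccccc12)C1CCCCC1`, 33 nM
compound 2, `C[C@H](NC(=O)c1c(CN2CCC(N3CCCCC3)CC2)c(-c2ccccc2)nc2ccccc12)C1CCCCC1`, 0.6 nM

In an assay on cell membranes for displacement of a labelled ligand from Substance-K receptor (Homo sapiens) (a lower number here means a stronger inhibitor, a higher number a weaker inhibitor), compound 2 gives 0.6 nM, the lowest of the two numbers; the nearest is compound 1 with 33 nM. The two share a core and differ only on a saturated ring carbon, where compound 1 carries an amino group and compound 2 a piperidin-1-yl group. That single change gave a 55-fold lower number from compound 1 to compound 2 (1.74 log units; beyond the scatter).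

Compound 3, `CC(C)C(=O)N1CCN(Cc2c(-c3ccccc3)nc3ccccc3c2C(=O)N[C@@H](C)C2CCCCC2)CC1`, is not yet measured. It differs from compound 2 by 4-(isopropylcarbonyl)piperazin-1-yl in place of 4-(piperidin-1-yl)piperidin-1-yl on a saturated chain carbon bound to an aromatic carbon. The group that leaves is the one whose piperidin-1-yl part drove the large gain seen as a 55-fold lower number from compound 1 to compound 2 (1.74 log units; beyond the scatter); the group that enters lacks that part and instead carries a carbonyl. Within the data shown here, only one step bears on this change, and it shows that the outer saturated ring matters strongly in this assay. A sizeable loss is therefore expected, though not necessarily back to the level of compound 1, as the estimated step of a 25-fold higher number from compound 2 to compound 3 (1.40 log units; beyond the scatter). For compound 3 in this assay the expected value is 15 nM, within a range from 2 nM to 100 nM.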

Compound 3, inhibition constant: 1.2 nM
Compound 3: the middle estimate sits 13-fold (1.10 log units) above what was measured; measured number outside the range, below it.
By their numbers in this assay, from the lowest: compounds 2 and 3 (each within the scatter of the next); then compound 1.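

In this assay, replacing 4-(piperidin-1-yl)piperidin-1-yl with 4-(isopropylcarbonyl)piperazin-1-yl gives a 2.0-fold higher number from compound 2 to compound 3 (0.30 log units; within the scatter), so the two groups cannot be told apart at this place on a saturated chain carbon bound to an aromatic carbon. Compared with the 4-aminopiperidin-1-yl group, the new group gives a 28-fold lower number from compound 1 to compound 3 (1.44 log units; beyond the scatter), which shows that a low number here does not depend on an outer piperidin-1-yl ring: a single piperazine ring carrying a carbonyl reaches the same level. Nothing measured here explains how two such different groups can give values that match within the scatter.

Only one acylated piperazine appears among these compounds, so the contribution of its isopropyl part remains open, and an acetyl or a cyclohexylcarbonyl group in its place would help to settle that. From the compounds shown here alone, whether the carbonyl itself counts is also open, a question that a 4-isobutylpiperazin-1-yl group, which has a plain chain and no carbonyl, could address.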